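This account rests on a few compounds, and the source may have more. Where it says the series, first, only, none or still open, it means among the compounds named here.

Compound 1 `CSc1ccc(CNc2nc(SC)nc3ncccc23)cc1` gives 7030 nM in a functional assay on HT-29 cells (Homo sapiens) for cytotoxicity, read by MTT assay, with a stated time of 72 h; on this read-out higher numbers stand for weaker inhibition of growth and lower numbers for stronger inhibition of growth.
Compound 2 `CCCCC[Se]c1nc([Se]CCCCC)c2ccccc2n1` gives > 100000 nM in this assay, which is a limit of the assay and not a number.
Compound 3 `COc1ccc(CNc2nc(SC)nc3ncccc23)cc1` gives > 100000 nM in this assay, again a limit of the assay rather than a number.

Compound 2 therefore stands at the weak end of what is shown: its value is one of the two that sit at the limit of > 100000 nM in this assay, at which 2 of the 3 values shown sit, so only an upper bound on its growth inhibition is known, and nothing can be said about how it ranks against compound 3. The step to compound 4 `CCCCC[Se]c1nc(N)c2ccccc2n1` is one nitrogen atom in place of a group of 6 heavy atoms (5 carbon, 1 selenium; no ring), on an aromatic carbon. For the measured compounds named here, the only measured step, an at least 14-fold higher number from compound 1 to compound 3 (1.15 log units; beyond the scatter), concerns a different change on the shared core of compound 1 and compound 3 and does not involve the selenium-bearing chain or an amino group, so it gives no direct guide to the change from compound 2 to compound 4. With compound 2 at the limit, the direction of the step cannot be read from the data, and a value near the limit, or again only a limit, is the most that can be expected. Compound 4 is therefore estimated at 80000 nM, within 20000 nM to 300000 nM, which would mean an expected step of an at least 1.2-fold lower number from compound 2 to compound 4 (0.09 log units; that floor lies within the scatter).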

Compound 4, concentration for total growth inhibition: > 100000 nM
Compound 4 gave a limit, no number; the forecaster's own chance of this, stated with the estimate: 60%; at least 1.2-fold (0.09 log units) between middle value and limit.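

For the compounds shown here, compound 4, like compound 2, gives a limit of the assay and not a number, so no step between the two can be read: the limit of > 100000 nM in this assay, at which 3 of the 4 values shown sit. The compounds shown leave open whether amino in place of the group of 6 heavy atoms (5 carbon, 1 selenium; no ring) changes growth inhibition at all in this assay.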